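A few compounds are considered here, and "the series" means these few. Any claim that something is new, unique, unknown or untested is made for them only; others in the source may bear on it.

Measured so far in an assay for inhibition of Fatty-acid amide hydrolase 1 (Rattus norvegicus); on this read-out higher numbers stand for weaker inhibition and lower numbers for stronger inhibition:
- compound 1 `COC(=O)c1ccc(-c2cnc(C(=O)CCc3ccc(-c4ccccc4)cc3)o2)nc1` gives 2.2 nM
- compound 2 `O=C(CCc1ccc(Oc2ccccc2)cc1)c1ncc(C(F)(F)F)o1` gives 2 nM
- compound 3 `O=C(CCc1ccc(COc2ccccc2)cc1)c1ncc(-c2cccc(-c3nnn[nH]3)n2)o1` gives 21 nM

Compound 1 stands second highest of the three, though its gap to compound 2 lies within the scatter; compound 3 sits well beyond it on the weaker side. Compound 4 `O=C(CCc1ccc(-c2ccccc2)cc1)c1ncc(C(=O)C(F)(F)F)o1` is not yet measured. It differs from compound 1 by one change: (trifluoromethyl)carbonyl in place of 5-(methoxycarbonyl)pyridin-2-yl on an aromatic carbon. Among the compounds with values here, no measured pair isolates this change, so the step from compound 1 to compound 4 in this assay is only an expectation; a small loss within or just beyond the scatter is the working guess, since the replacement is a much smaller group. Compound 4 is expected at 5 nM, range 1 nM to 30 nM, a step of a 2.3-fold higher number from compound 1 to compound 4 (0.36 log units; beyond the scatter).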

Compound 4, inhibition constant: 8 nM
Estimate against measurement, compound 4: 1.6-fold (0.20 log units) below; the range from low to high includes it.
By their numbers in this assay, from the lowest: compounds 2 and 1 (each within the scatter of the next); then compound 4; then compound 3.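

In this assay, the aromatic carbon next to the ring oxygen now has its first readable step: (trifluoromethyl)carbonyl in place of 5-(methoxycarbonyl)pyridin-2-yl gives a 3.6-fold higher number from compound 1 to compound 4 (0.56 log units; beyond the scatter). With no ring in this group, compound 4 still gives 8 nM, so a ring at this place is not needed for a number of that size. Nothing measured here accounts for the size of the step.

As far as these compounds go, whether the step rests with the ring of the leaving group or with its methoxycarbonyl stays open. A carboxylic acid in place of that methoxycarbonyl, or plain pyridin-2-yl, would separate the two.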